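Resolving a tetrahydro-benzopyran urea into one enantiomer

The source may hold more compounds than are shown below. What is called first, only, known or untested is meant among the compounds shown, and "the series" means these compounds.

Two ureas built on a shared core have been measured in a functional assay for antagonist activity at transient receptor potential cation channel subfamily V member 1 (Homo sapiens), read by calcium flux; a higher number here means a weaker inhibitor, a lower number a stronger inhibitor. Compound 1 `O=C(Nc1cccc2[nH]ncc12)N[C@@H]1CCOc2cc(C(F)(F)F)ccc21` gives 4 nM in this assay. Compound 2 `CC(C)(C)c1ccc2c(c1)OCCC2NC(=O)Nc1cccc2[nH]ncc12`, which carries a tert-butyl group in place of the trifluoromethyl group, gives 43 nM; this is the higher of the two numbers, and its gap to compound 1 lies beyond the usual scatter of repeated measurements.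

Compound 3 `CC(C)(C)c1ccc2c(c1)OCC[C@H]2NC(=O)Nc1cccc2[nH]ncc12` is the same molecule as compound 2 apart from how the saturated ring carbon is drawn: the two compounds have the same atoms and bonds; at least one stereo element is drawn with a configuration in one of them and without one in the other: 1 of 1 stereo elements differ; a stereocentre at a saturated ring carbon is drawn without a configuration in compound 2 and R in compound 3. In plain terms, compound 2 is a mixture of two mirror-image forms and compound 3 is one of them. If only one form carries most of the activity, isolating it should lower the number by about half; if the wrong one was picked, the number should rise sharply. Compound 1 shows that the shared core can reach a low number with a single drawn configuration. The step from compound 2 to compound 3 is expected to be a modest improvement of a 2.0-fold lower number from compound 2 to compound 3 (0.29 log units; within the scatter), and compound 3 is estimated at 22 nM, within a range from 8 nM to 60 nM.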

Compound 3, half-maximal inhibitory concentration: 31 nM
For compound 3 the middle estimate is 1.4-fold (0.15 log units) below the measured one; measured number inside the range.
By their numbers in this assay, from the lowest: compound 1; then compounds 3 and 2 (each within the scatter of the next).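

In this assay, defining the saturated ring carbon as R gives a 1.4-fold lower number from compound 2 to compound 3 (0.14 log units; within the scatter), which lies within the scatter, so the single form and the mixture cannot be told apart at this position. The larger result is the clean comparison with compound 1, which previously differed from the mixture in its drawn configuration as well as its aromatic substituent: with the configuration now drawn, one change remains, tert-butyl in place of trifluoromethyl on an aromatic carbon, and it gives a 7.8-fold higher number from compound 1 to compound 3 (0.89 log units; beyond the scatter), a step beyond the scatter. The reading of the first step as a test of stereochemistry, and of the second as a test of the aromatic group alone, rests on one structural fact: the fact that one of compounds 2 and 3 is drawn with a defined configuration and the other without, at the place where they differ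

As far as these compounds go, what remains open is how the other mirror-image form of compound 3 behaves, and so whether either form carries more of the activity than the other. Also open, from the compounds shown here alone, is where a nitrile or a methoxy group on that same aromatic carbon would fall relative to trifluoromethyl and tert-butyl, with the rest of the molecule unchanged.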